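Adding a Phenyl to the Ester Side Chain of Compound 1

This account rests on a few compounds, and the source may have more. Where it says the series, first, only, none or still open, it means among the compounds named here.

Measured compounds in a functional assay on HeLa cells (Homo sapiens) for cytotoxicity, read by MTT assay; on this read-out lower numbers stand for stronger inhibition and higher numbers for weaker inhibition:
- compound 1 `CC(C)=CC[C@@H](OC(=O)CCO)C1=CC(=O)c2c(O)ccc(O)c2C1=O` gives 67600 nM
- compound 2 `CC(C)=CC[C@@H](OC[C@@H](C)O)C1=CC(=O)c2c(O)ccc(O)c2C1=O` gives 22500 nM
- compound 3 `CC(C)=CC[C@@H](OCC(C)O)C1=CC(=O)c2c(O)ccc(O)c2C1=O` gives 24700 nM

Compound 1 stands with the highest of the three numbers in this assay, so it is the weakest of the three. Compound 2 and compound 3 sit close together; the difference between them is a 1.1-fold higher number from compound 2 to compound 3 (0.04 log units; within the scatter), and the two drawings differ only in that (the fact that one of compounds 2 and 3 is drawn with a defined configuration and the other without, at the place where they differ).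

The unmeasured compound 4 `CC(C)=CC[C@@H](OC(=O)CC(O)c1ccccc1)C1=CC(=O)c2c(O)ccc(O)c2C1=O` differs from compound 1 in one place: phenyl in place of hydrogen on a saturated chain carbon bound to an oxygen on a saturated carbon and a saturated chain carbon. This keeps the (2-hydroxyethyl)carbonyl ester of compound 1 in place and only adds a ring to it.

The measured steps are of a different kind. In a 3.0-fold lower number from compound 1 to compound 2 (0.48 log units; beyond the scatter) and a 2.7-fold lower number from compound 1 to compound 3 (0.44 log units; beyond the scatter) the ester is exchanged for a 2-hydroxypropyl ether, and both gave modest gains. Neither step speaks to a phenyl added onto an otherwise unchanged ester, so they bear on compound 4 only loosely.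

With no closer guide, the change from compound 1 to compound 4 is expected to stay within the scatter, as a 1.4-fold lower number from compound 1 to compound 4 (0.13 log units; within the scatter). Compound 4 is therefore estimated at 50000 nM, with a range from 15000 nM to 160000 nM.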

Compound 4, half-maximal inhibitory concentration: 44500 nM
Compound 4: the middle estimate sits 1.1-fold (0.05 log units) above what was measured, within the range that was stated.
By their numbers in this assay, from the lowest: compounds 2, 3, 4 and 1 (each within the scatter of the next, the first and the last beyond it).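

The earlier compounds shown here exchanged the ester as a whole for a 2-hydroxypropyl ether, whereas compound 4 keeps the ester and puts phenyl in place of hydrogen on the saturated chain carbon bound to the oxygen. In this assay, this addition stays within the scatter, as a 1.5-fold lower number from compound 1 to compound 4 (0.18 log units; within the scatter), so this position takes a phenyl with no change that can be told from repeat-measurement noise. Nothing shown here explains why so large an addition leaves the number within the scatter.

From the compounds shown here alone, whether a benzyl group, a pyridine ring or a carboxylic acid at this carbon would also stay within the scatter remains open. Also open, going by these compounds, is whether a phenyl added to the 2-hydroxypropyl ether of compound 2 would behave as it does on the ester.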